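A few compounds are considered here, and "the series" means these few. Any claim that something is new, unique, unknown or untested is made for them only; others in the source may bear on it.

Measured compounds in a functional assay on L-428 cells (Homo sapiens) for cytotoxicity, read by XTT assay, with a stated time of 48 h; on this read-out higher numbers stand for weaker inhibition and lower numbers for stronger inhibition:
Compound 1, `CN(C)c1ccc(/C=C/C=C/C(=O)N2CCCCC2)cc1`, gives 0.39 ug/mL.
Compound 2, `O=C(/C=C/C=C/c1ccccc1)N1CCCCC1`, gives 43.3 ug/mL.

Compound 2 stands at the highest of the two numbers. Its nearest neighbour is compound 1, which differs from it in only one place, a dimethylamino group where compound 2 carries a hydrogen, and the step between them, a 110-fold higher number from compound 1 to compound 2 (2.05 log units; beyond the scatter), shows that taking that group away raised the number a great deal.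

Compound 3, `COc1ccc(/C=C/C=C/C(=O)N2CCCCC2)cc1`, is the next step from compound 2: methoxy in place of hydrogen on an aromatic carbon. Within the data shown here, the only measured step that bears on this change is a 110-fold higher number from compound 1 to compound 2 (2.05 log units; beyond the scatter), where a group at the same place was exchanged for hydrogen and the number moved by a large amount. Methoxy is a different group from dimethylamino, so the size of its effect cannot be read from that single step; what the step does suggest is that placing a group here again is expected to move the number downward, beyond the scatter, though probably by less than the dimethylamino step did. Compound 3 is therefore expected to give 8 ug/mL, with a range from 2 ug/mL to 30 ug/mL. The expected step is a 5.4-fold lower number from compound 2 to compound 3 (0.73 log units; beyond the scatter).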

Compound 3, half-maximal inhibitory concentration: 16.9 ug/mL
Estimate against measurement, compound 3: 2.1-fold (0.32 log units) below, and the stated range covers the measured number.
By their numbers in this assay, from the lowest: compound 1; then compound 3; then compound 2.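

In this assay, among these compounds, methoxy at this place, on the aromatic carbon para to a large group, also lowers the number (a 2.6-fold lower number from compound 2 to compound 3 (0.41 log units; beyond the scatter)), so the earlier drop is no longer the only sign that a group here can matter. The change is modest, however, and replacing dimethylamino directly with methoxy leaves a large gap (a 43-fold higher number from compound 1 to compound 3 (1.64 log units; beyond the scatter)), so the two groups are far from interchangeable here and compound 1 remains the strongest of the three. No measurement shown explains why these two groups differ so widely.

As far as these compounds go, what remains open is how narrow this preference is: with only hydrogen, methoxy and dimethylamino to compare, three points cannot show whether the nitrogen, its two methyl groups or some other feature of dimethylamino accounts for the low number. A plain amino group, a diethylamino group, or a group without nitrogen or oxygen such as chlorine at the same place would help to separate these possibilities.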